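The source may hold more compounds than are shown below. What is called first, only, known or untested is meant among the compounds shown, and "the series" means these compounds.

Measured so far in an in vitro functional assay on 1321-N1 cells for antagonist activity at transient receptor potential cation channel subfamily V member 1 (Homo sapiens), read by FLIPR and calcium flux; a lower number here means a stronger inhibitor, a higher number a weaker inhibitor:

compound 1, `O=C(Nc1ccc(Cl)c(F)c1)C1=CCN(c2ncccc2Cl)CC1`: 78 nM
compound 2, `O=C(Nc1ccc(Cl)c(Cl)c1)C1=CCN(c2ncccc2Cl)CC1`: 124 nM
compound 3, `O=C(Nc1ccc(Cl)cc1F)C1=CCN(c2ncccc2Cl)CC1`: not yet measured

Among the measured compounds shown here, compound 2 stands at the upper end of the two numbers recorded in this assay, with compound 1 as its only neighbour; the step of a 1.6-fold higher number from compound 1 to compound 2 (0.20 log units; within the scatter) does not separate the two beyond the scatter. The change to compound 3 is 4-chloro-2-fluorophenyl in place of 3,4-dichlorophenyl on an amide-type nitrogen. For the measured compounds named here, the only measured step concerns this same ring, the exchange of fluoro for chloro on one aromatic carbon, and it was a 1.6-fold higher number from compound 1 to compound 2 (0.20 log units; within the scatter), within the scatter. Going by the values given here, no measured pair covers a rearrangement of the halogen pattern on the anilide ring, so the expectation rests on the small size of that one step and on the shared core. A step of similar order, with some allowance for a weaker result, is expected; a move far beyond the scatter in either direction has no support in the two numbers available. Compound 3 is therefore estimated at 160 nM, within 45 nM to 600 nM, corresponding to an expected step of a 1.3-fold higher number from compound 2 to compound 3 (0.11 log units; within the scatter).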

Compound 3, half-maximal inhibitory concentration: 618 nM
Compound 3: middle estimate off by 3.9-fold (0.59 log units), on the low side; the whole stated range lies below it.
By their numbers in this assay, from the lowest: compounds 1 and 2 (each within the scatter of the next); then compound 3.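

In this assay, the ring on the amide-type nitrogen responds to the arrangement of its halogens and not only to their identity: 4-chloro-2-fluorophenyl in place of 3,4-dichlorophenyl gives a 5.0-fold higher number from compound 2 to compound 3 (0.70 log units; beyond the scatter) on this position, while the same group in place of its isomer 4-chloro-3-fluorophenyl gives a 7.9-fold higher number from compound 1 to compound 3 (0.90 log units; beyond the scatter) on the same shared core. The exchange of fluoro for chloro between compound 1 and compound 2 stayed within the scatter, so that pair alone gave no sign of this sensitivity, whereas compound 3 is the weakest inhibitor of the three, beyond the scatter from both others. No supporting measurement is available to account for this result.

Open, from the compounds shown here alone, is whether the loss seen with 4-chloro-2-fluorophenyl is specific to fluoro at that place on the ring or would also appear with another group there, such as methyl or methoxy. Also open, going by these compounds, is whether the same dependence on the substitution pattern would hold with a different group in place of the chloro shared by all three rings, such as a nitrile or trifluoromethyl.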